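The source may hold more compounds than are shown below. What is called first, only, known or untested is meant among the compounds shown, and "the series" means these compounds.

Measured so far:
- compound 1, `CC(C)=CC[C@H](OC(=O)C=C(C)C)C1=CC(=O)c2c(O)ccc(O)c2C1=O`: 680 nM in a functional assay on SK-BR-3 cells (Homo sapiens) for cytotoxicity, read by MTT assay, with a stated time of 48 h; a higher number here means a weaker inhibitor, a lower number a stronger inhibitor
- compound 2, `COc1ccc(O)c2c1C(=O)C=C([C@H](CC=C(C)C)OC(C)=O)C2=O`: 440 nM in this assay

In this assay compound 2 stands at 440 nM and compound 1 at 680 nM; the gap between them lies within the scatter, so the two cannot be told apart on these numbers. Compound 3, `COc1ccc(O)c2c1C(=O)C=C([C@H](CC=C(C)C)OC(=O)C=C(C)C)C2=O`, is not yet measured. It differs from compound 2 by 2-methylprop-1-en-1-yl in place of methyl on a carbonyl carbon. Compound 1 already carries the same ester group on a different core and sits close to compound 2, so no step beyond the scatter is expected. The expected step of a 1.0-fold higher number from compound 2 to compound 3 (0.01 log units; within the scatter) is small. Compound 3 is estimated at 450 nM, with a range from 200 nM to 1000 nM.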

Compound 3, half-maximal inhibitory concentration: 830 nM
Compound 3: the middle estimate sits 1.8-fold (0.27 log units) below what was measured; measured number inside the range.
By their numbers in this assay, from the lowest: compounds 2, 1 and 3 (each within the scatter of the next).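

In this assay, 2-methylprop-1-en-1-yl in place of methyl on a carbonyl carbon gives a 1.9-fold higher number from compound 2 to compound 3 (0.28 log units; within the scatter), so this position shows no step beyond the scatter for this change. With that ester group held fixed, methyl in place of hydrogen on an oxygen on an aromatic ring gives a 1.2-fold higher number from compound 1 to compound 3 (0.09 log units; within the scatter), so this second change cannot be read as a step either. No independent data bear on these results. Open, from the compounds shown here alone, is whether a longer chain, an amine or a carboxylic acid at the carbonyl carbon would give a step beyond the scatter.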